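This account rests on a few compounds, and the source may have more. Where it says the series, first, only, none or still open, it means among the compounds named here.

Compound 1 `Nc1nc(-c2ccccc2)cn1/N=C/c1cc2ccccc2nc1Cl` and compound 2 `Nc1nc(-c2ccc(Cl)cc2)cn1/N=C/c1cc2ccccc2nc1Cl` share one core and differ by chloro in place of hydrogen on an aromatic carbon. In a functional assay on HCT-116 cells (Homo sapiens) for cytotoxicity, read by MTT assay, with a stated time of 48 h (on this read-out higher numbers stand for weaker inhibition and lower numbers for stronger inhibition), compound 1 gives 6920 nM. Compound 2 reaches only the limit of this assay, > 50000 nM, so no number is known for it. That step, an at least 7.2-fold higher number from compound 1 to compound 2 (0.85 log units; beyond the scatter), places compound 2 at the limit of > 50000 nM in this assay, at which 1 of the 2 values shown sits. Compound 3 `Nc1nc(-c2ccc(Br)cc2)cn1/N=C/c1cc2ccccc2nc1Cl` carries bromo in place of chloro on an aromatic carbon. Within the data shown here, no measured step tests this exchange of one halogen for another, and since compound 2 itself stands at a limit, the single measured step, from compound 1 to compound 2, offers no direction for it. For compound 3 the expected step that the limit leaves unreadable from compound 2 to compound 3 is therefore not beyond the scatter. Compound 3 is thus estimated at 60000 nM, within a range from 20000 nM to 200000 nM, and most likely it again returns only a limit in this assay.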

Compound 3, half-maximal inhibitory concentration: > 50000 nM
Compound 3 was reported as a limit (the forecaster's own chance of this, stated with the estimate: 75%); the middle value is on the limit's open side.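

With bromo in place of hydrogen on this aromatic carbon, this assay gives an at least 7.2-fold higher number from compound 1 to compound 3 (0.85 log units; beyond the scatter). The shift seen with chloro is therefore not confined to that one halogen: both halogens at this place, para to a large group, lie beyond the scatter from compound 1 in the same direction. The step between compound 2 and compound 3 cannot be read, so the two halogens cannot be put in any order: the limit of > 50000 nM in this assay, at which 2 of the 3 values shown sit.

The compounds shown leave open how far past the limit compound 2 and compound 3 lie. They also leave open whether a measurable value returns with a fluoro, a methoxy, an amine or a carboxylic acid on this carbon.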